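The source may report more compounds than this note shows. Statements on the series, on what has been measured and on what is new or still open speak of the compounds shown alone.

Measured so far:
Compound 1 `CCCCCCCCCCCCCCCCNC(=O)[C@H](O)CO[C@H]1O[C@H](CO)[C@@H](O)[C@H](O)[C@H]1NC(C)=O` — in a functional assay on MDA-MB-231 cells (Homo sapiens) for cytotoxicity, read by sulforhodamine B assay, with a stated time of 72 h (a higher number here means a weaker inhibitor, a lower number a stronger inhibitor), compound 1 gives > 10000 nM, which is a limit of the assay and not a number.
Compound 2 `CCCCCCCCCCCCCCCCCNC(=O)[C@H](O)CO[C@H]1O[C@H](CO)[C@@H](O)[C@H](O)[C@H]1NC(C)=O` — in this assay compound 2 gives > 10000 nM, again a limit of the assay and not a number.

Going by the values given here, compound 2 therefore stands only at a limit in this assay; the one other value shown is a limit as well, both sitting at the limit of > 10000 nM in this assay, at which 2 of the 2 values shown sit. Among the compounds with values here, the single measured step, a step that the two limits leave unreadable from compound 1 to compound 2, is left unreadable by the two limits and gives no size to work from.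

Compound 3 `CCCCCC/C=C\CCCCCCCCNC(=O)[C@H](O)CO[C@H]1O[C@H](CO)[C@@H](O)[C@H](O)[C@H]1NC(C)=O` differs from compound 2 by a group of 8 heavy atoms (8 carbon; no ring) in place of a group of 9 heavy atoms (9 carbon; no ring), on a saturated chain carbon, eight bonds along the chain from an amide-type nitrogen. Within the data shown here, no measured step touches a change of this kind, and the one step that exists has no readable size. With nothing pointing away from the limit, compound 3 is expected to come out at or near the same limit. The estimate for compound 3 in this assay is 15000 nM, with a range from 5000 nM to 50000 nM. The step this estimate implies is a step that the limit leaves unreadable from compound 2 to compound 3, expected to stay within the scatter.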

Compound 3, half-maximal inhibitory concentration: > 10000 nM
Compound 3: no number, only a limit (the forecaster's own chance of this, stated with the estimate: 75%); the middle value lies beyond the limit too.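

No step among compound 1, compound 2 and compound 3 can be read in this assay: the limit of > 10000 nM in this assay, at which 3 of the 3 values shown sit.

The compounds shown leave open whether any change to the chain on the shared core would give a measurable value in this assay, and how large such a step would be.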